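Removing the ester acyl group from compound 1

A few compounds are considered here, and "the series" means these few. Any claim that something is new, unique, unknown or untested is made for them only; others in the source may bear on it.

Compound 1 `O=C(OC1(C(=O)Nc2ccc([N+](=O)[O-])cc2)CCCCC1)c1ccccc1I` gives 396 nM in an ADME assay on WI-38 cells (Homo sapiens) for inhibition, read by MTT assay, with a stated time of 72 h (a lower number here means a stronger inhibitor, a higher number a weaker inhibitor), the highest number among the three measured compounds. Its nearest neighbour is compound 2 `CCOC(=O)c1ccccc1C(=O)OC1(C(=O)Nc2ccc([N+](=O)[O-])cc2)CCCCC1` with 386 nM, a step of a 1.0-fold lower number from compound 1 to compound 2 (0.01 log units; within the scatter), and its furthest is compound 3 `O=C(/C=C/c1ccccc1)OC1(C(=O)Nc2ccc([N+](=O)[O-])cc2)CCCCC1` with 41 nM, a step of a 9.7-fold lower number from compound 1 to compound 3 (0.98 log units; beyond the scatter). Compound 4 `O=C(Nc1ccc([N+](=O)[O-])cc1)C1(O)CCCCC1` differs from compound 1 by hydrogen in place of (2-iodophenyl)carbonyl on an oxygen on a saturated carbon. Neither measured step bears on this change directly: the step from compound 1 to compound 2 and the step from compound 1 to compound 3 alter what sits on the carbonyl carbon, whereas the carbonyl itself stays; here the whole acyl group is lost and only a hydroxyl remains. Among the measured compounds shown here, the data therefore give no step of the same kind, so the estimate rests on compound 1 alone and is broad. A higher number, that is weaker inhibition, is expected for compound 4, with a step of a 3.8-fold higher number from compound 1 to compound 4 (0.58 log units; beyond the scatter), giving an estimated 1500 nM in a range from 250 nM to 10000 nM.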

Compound 4, half-maximal inhibitory concentration: 1220 nM
Compound 4: the middle estimate sits 1.2-fold (0.09 log units) above what was measured, and the stated range covers the measured number.
By their numbers in this assay, from the lowest: compound 3; then compounds 2 and 1 (each within the scatter of the next); then compound 4.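

In this assay, among the compounds shown here, the earlier compounds changed only what sits on the carbonyl carbon, whereas compound 4 loses the whole (2-iodophenyl)carbonyl group, with hydrogen in its place on the oxygen, and this gives a 3.1-fold higher number from compound 1 to compound 4 (0.49 log units; beyond the scatter). Inhibition therefore weakens beyond the scatter but does not disappear, since the hydroxyl compound, compound 4, still gives a measurable 1220 nM in this read-out. Nothing in the data shown gives a reason for this step.

The compounds shown leave open whether a small acyl group such as acetyl, or a methyl ether on the same oxygen, would give a number closer to that of compound 1 or that of compound 4. They also leave open how an amine in place of the hydroxyl would compare.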